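The source may hold more compounds than are shown below. What is called first, only, known or untested is meant among the compounds shown, and "the series" means these compounds.

Two compounds share one core and differ only in the aromatic ring attached to the carbon that carries the double bond to nitrogen. Compound 1 `O/N=C(/CCN1CCN(c2ccccn2)CC1)c1ccccc1Cl` carries a chlorine-bearing ring there, and in a functional assay on HEK293 cells with D(4) dopamine receptor (Homo sapiens) as the target, read by FLIPR (on this read-out higher numbers stand for an effect only at larger amounts of compound and lower numbers for an effect already at smaller amounts), compound 1 gives 25 nM. Compound 2 `Cc1ccccc1/C(CCN1CCN(c2ccccn2)CC1)=N/O` carries a methyl-bearing ring in the same place, and in this assay compound 2 gives 4.2 nM. Of the two numbers, that of compound 2 is the lower one, and its distance from compound 1 lies beyond the usual scatter, so compound 2 acts at the smaller amount.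

Compound 3 `O/N=C(\CCN1CCN(c2ccccn2)CC1)c1cc(F)cc(F)c1` has not been measured yet. It differs from compound 2 in a single place: 3,5-difluorophenyl in place of 2-methylphenyl on a carbon with a double bond to nitrogen. Within the data shown here, no pair of measured compounds shows this particular exchange, so the expectation has to rest on the two values given. Because compound 1 gives 25 nM and compound 2 gives 4.2 nM, the ring on that carbon clearly matters, and a ring without any group of the kind that compound 2 carries is expected to move the number upward, beyond the scatter, as a 7.1-fold higher number from compound 2 to compound 3 (0.85 log units; beyond the scatter). For compound 3 the expected value in this assay is 30 nM, with a likely range from 8 nM to 120 nM.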

Compound 3, half-maximal effective concentration: 19.4 nM
Compound 3: middle estimate off by 1.5-fold (0.19 log units), on the high side; the range from low to high includes it.
By their numbers in this assay, from the lowest: compound 2; then compounds 3 and 1 (each within the scatter of the next).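

In this assay, among these compounds, this is the first exchange read as a single step: 3,5-difluorophenyl in place of 2-methylphenyl on the carbon with a double bond to nitrogen gives a clear but modest loss (a 4.6-fold higher number from compound 2 to compound 3 (0.66 log units; beyond the scatter)). So this position accepts a ring with two fluorine atoms and no methyl group while the compound still acts at low nanomolar amounts, yet that ring does not match the methyl-bearing ring of compound 2. Compound 3 at 19.4 nM also lies within the usual scatter of compound 1 at 25 nM, so the fluorine-bearing and chlorine-bearing rings cannot be told apart here, and nothing at hand explains why either differs from the methyl-bearing ring.

This single exchange changes both the kind of group on the ring and the number of such groups, so the share of each in the step stays unresolved. A plain phenyl ring with no added group, or a ring bearing a methoxy group, would be the next informative comparison at this carbon.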